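Replacing 2-hydroxyethyl with 2-hydroxycyclohexyl

A few compounds are considered here, and "the series" means these few. Any claim that something is new, unique, unknown or untested is made for them only; others in the source may bear on it.

Measured in a functional assay on PC-3M cells (Homo sapiens) for antiproliferative activity, read by microscopy, with a stated time of 24 h; on this read-out lower numbers stand for stronger inhibition and higher numbers for weaker inhibition:
- compound 1 `COc1ccc(-c2c(-c3ccc(OC)cc3)n(Cc3ccccc3)c3ncn(CCCO)c(=N)c23)cc1`: > 20000 nM
- compound 2 `COc1ccc(-c2c(-c3ccc(OC)cc3)n(Cc3ccccc3)c3ncn([C@H]4CC[C@H](OC)CC4)c(=N)c23)cc1`: > 20000 nM
- compound 3 `COc1ccc(-c2c(-c3ccc(OC)cc3)n(Cc3ccccc3)c3ncn(CCO)c(=N)c23)cc1`: > 20000 nM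

Compound 3 gives only a limit, > 20000 nM, not a number. Going by the values given here, the series so far rests on (the limit of > 20000 nM in this assay, at which 3 of the 3 values shown sit).

Compound 4 `COc1ccc(-c2c(-c3ccc(OC)cc3)n(Cc3ccccc3)c3ncn([C@@H]4CCCC[C@H]4O)c(=N)c23)cc1` changes one group of compound 3: 2-hydroxycyclohexyl in place of 2-hydroxyethyl on an aromatic nitrogen.

Compound 2, with 4-methoxycyclohexyl on that nitrogen, likewise gives only a limit, > 20000 nM. The closest measured change is a step that the two limits leave unreadable from compound 2 to compound 3. The others are a step that the two limits leave unreadable from compound 1 to compound 2 and a step that the two limits leave unreadable from compound 1 to compound 3. None offers a size or direction to carry over, so no clear shift is expected in this assay.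

The expected change is a number no higher from compound 3 to compound 4 (the limit leaves the size open).

Compound 4 is estimated at 20000 nM, within 8000 nM to 40000 nM, and will probably be reported as a limit again.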

Compound 4, half-maximal inhibitory concentration: > 20000 nM
Compound 4 gave a limit, no number; the forecaster's own chance of this, stated with the estimate: 75%; the middle value sits exactly at the limit.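

In this assay, going by these compounds alone, compound 4 gives > 20000 nM as a limit and not a number, so no step linking it to compound 1, compound 2 or compound 3 can be read. The compounds shown leave open whether any group on that aromatic nitrogen gives a readable half-maximal inhibitory concentration: the limit of > 20000 nM in this assay, at which 4 of the 4 values shown sit.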